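This account rests on a few compounds, and the source may have more. Where it says the series, first, only, none or still open, it means among the compounds named here.

Cytotoxicity is followed here in a functional assay on SMMC-7721 cells (Homo sapiens) for cytotoxicity, read by MTT assay, with a stated time of 72 h (on this read-out lower numbers stand for stronger inhibition and higher numbers for weaker inhibition), and three compounds have results so far. Compound 1 `COc1ccc(NC(=O)CSC(=S)N[C@H]2CCOC2=O)cc1` shows > 128000 nM as a limit of the assay and not a number. Compound 2 `CCCCCCCCSC(=S)N[C@H]1CCOC1=O` gives 65100 nM as a measured number. Compound 3 `O=C(CCl)Nc1ccc(C(=O)/C=C/c2ccccc2)cc1` gives 12600 nM as the lowest of the two actual numbers, and its gap to compound 2 lies beyond the usual scatter.

The next compound keeps nearly all of compound 3. Compound 4 `O=C(CCl)Nc1ccc(C(=O)/C=C/c2cccc(Cl)c2)cc1` carries a single change, chloro in place of hydrogen on an aromatic carbon and in words this is chloro in place of hydrogen on an aromatic carbon, turning phenyl to 3-chlorophenyl. Within the data shown here, no pair of measured compounds shows what this swap does, so the expectation stays cautious and starts from compound 3 at 12600 nM in the absence of a direct comparison. In this assay the expected step of a 1.4-fold lower number from compound 3 to compound 4 (0.15 log units; within the scatter) is small, a slight move towards a lower number that may not clear the scatter. Compound 4 is estimated at 9000 nM with an expected range from 3500 nM to 22000 nM when it is measured.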

Compound 4, half-maximal inhibitory concentration: 7760 nM
For compound 4 the middle estimate is 1.2-fold (0.06 log units) above the measured one, and the stated range covers the measured number.
By their numbers in this assay, from the lowest: compounds 4 and 3 (each within the scatter of the next); then compound 2. At a limit, above all of these: compound 1.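

In this assay, among these compounds, the first comparison between two compounds differing in one place is a 1.6-fold lower number from compound 3 to compound 4 (0.21 log units; within the scatter) and so gives a first direct reading of this change. On this single pair, turning phenyl to 3-chlorophenyl, with the chloro on an aromatic carbon meta to a large group, gives no change that can be told apart from the ordinary spread of repeated measurements. Nothing measured here bears on why the step has this size.

Still open, on these data alone, is whether an amine, a carboxylic acid or a fluoro group on this ring, or a chloro elsewhere on it, would give a step beyond the scatter. As far as these compounds go, whether the same swap gives a similar step on a different core also remains open.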